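Ethyl ester to free acid across two cores: toxicity notes

The source may report more compounds than this note shows. Statements on the series, on what has been measured and on what is new or still open speak of the compounds shown alone.

Compound 1 `C=C(C(=O)OCC)C(O)c1ccc(Cl)cc1Cl` and compound 2 `C=C(C(=O)O)C(O)c1ccc(Cl)cc1Cl` share one core; compound 3 `CCOC(=O)C(C)Cc1ccccc1Cl` and compound 4 `CC(Cc1ccccc1Cl)C(=O)O` share another. The difference between the two cores is not broken down here.

In an ADME assay on THP-1 cells (Homo sapiens) for cytotoxicity, read by MTT assay, with a stated time of 72 h (on this read-out lower numbers stand for higher toxicity in this test and higher numbers for lower toxicity in this test), compound 1 gives 68.3 uM. Compound 2 reaches only a limit of this assay, > 100 uM. The change between them is hydrogen in place of ethyl on an oxygen next to a carbonyl group, and it carries an at least 1.4-fold higher number from compound 1 to compound 2 (0.16 log units; that floor lies within the scatter). Compound 3 also reaches only a limit of this assay, > 100 uM. Among the measured compounds shown here, the series is thus dominated by the limit of > 100 uM in this assay, at which 2 of the 3 values shown sit, so the one numbered value of compound 1 is the only fixed point.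

From compound 3 to compound 4 the change is hydrogen in place of ethyl on an oxygen next to a carbonyl group, the same change as from compound 1 to compound 2, made at the same place and with the same groups leaving and entering. It occurs twice in all among the compounds shown.

In this assay the step is expected to be a step that the limit leaves unreadable from compound 3 to compound 4. That expectation rests on compound 3 already standing at > 100 uM, and on the measured step in the other pair, an at least 1.4-fold higher number from compound 1 to compound 2 (0.16 log units; that floor lies within the scatter), which did not lower the number. Compound 4 is therefore expected to give about 160 uM, with a plausible span from 90 uM to 400 uM, and most likely to be reported only as a limit rather than a number.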

Compound 4, half-maximal toxic concentration: > 100 uM
Compound 4: a limit, no number; the forecaster's own chance of this, stated with the estimate: 85%; the middle value does not contradict the limit.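

Compound 3 and compound 4 both sit at a limit in this assay, so no size can be read for the step between them: the limit of > 100 uM in this assay, at which 3 of the 4 values shown sit.

The compounds shown leave open how far hydrogen in place of ethyl moves the number on either core, and whether the two cores respond alike, with compound 1 the only one carrying a number.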